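The source may report more compounds than this note shows. Statements on the series, on what has been measured and on what is new or still open speak of the compounds shown alone.

For the measured compounds named here, in an ADME assay on the whole organism (plasma) for pharmacokinetics, with Mus musculus as the target, at a dose of 5 mg/kg by the intravenous route (a lower number here means less compound in the circulation, a higher number more compound in the circulation at the dose given), compound 1 `O=C1Nc2c(ccc(F)c2F)C1(c1ccc(O)cc1)c1cccs1` gives 395 ng.h/mL, the lower of the two numbers measured so far, and compound 2 `O=C1Nc2c(ccc(F)c2F)C1(c1ccc(O)cc1)C1CCCC1` gives 1850 ng.h/mL. Compound 3 `O=C1Nc2c(ccc(F)c2F)C1(c1ccc(O)cc1)C1CCCCC1` has cyclohexyl in place of thiophen-2-yl on a saturated ring carbon. Going by the values given here, the one measured step that bears on this change is a 4.7-fold higher number from compound 1 to compound 2 (0.67 log units; beyond the scatter), which lies beyond the scatter and puts cyclopentyl in place of thiophen-2-yl on that carbon. On the strength of a 4.7-fold higher number from compound 1 to compound 2 (0.67 log units; beyond the scatter), a step of similar size towards a higher number in this assay is expected. The expected step is a 4.1-fold higher number from compound 1 to compound 3 (0.61 log units; beyond the scatter). For compound 3 the estimated value is 1600 ng.h/mL, with an expected range from 650 ng.h/mL to 3800 ng.h/mL.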

Compound 3, area under the concentration-time curve: 3550 ng.h/mL
For compound 3 the middle estimate is 2.2-fold (0.35 log units) below the measured one; the range from low to high includes it.
By their numbers in this assay, from the lowest: compound 1; then compounds 2 and 3 (each within the scatter of the next).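

In this assay, a second non-aromatic ring of carbon only on the saturated ring carbon again beats thiophen-2-yl, with cyclohexyl giving a 9.0-fold higher number from compound 1 to compound 3 (0.95 log units; beyond the scatter) and so extending the one earlier observation. The ring size of the two saturated groups makes no readable difference at this position, since cyclohexyl for cyclopentyl gives a 1.9-fold higher number from compound 2 to compound 3 (0.28 log units; within the scatter) and stays within the scatter. Nothing available explains the gain over thiophen-2-yl. Still open, as far as these compounds go, is whether a piperidine ring carrying an amine or an open isobutyl chain would hold the higher number. From the compounds shown here alone, whether phenyl would behave like thiophen-2-yl also remains open.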